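A few compounds are considered here, and "the series" means these few. Any claim that something is new, unique, unknown or untested is made for them only; others in the source may bear on it.

Measured compounds:
compound 1 `N/C(=N\NC(=S)N1CCOCC1)c1ccccn1`: 4700 nM
compound 2 `N/C(=N\NC(=S)N1CCCC1)c1ccc(F)cn1`: 900 nM
compound 3 `N/C(=N\NC(=S)N1CCSCC1)c1ccc(F)cn1`: 21400 nM

All three were tested in a functional assay on MCF7 cells (Homo sapiens) for cytotoxicity, read by MTT assay, with a stated time of 72 h; on this read-out higher numbers stand for weaker inhibition and lower numbers for stronger inhibition. Compound 3 stands at the highest number of the three; its nearest neighbour is compound 1, and compound 2 lies furthest away, so compound 3 is the weakest of the measured set. Compound 4 `N/C(=N\NC(=S)N1CCOCC1)c1ccc(F)cn1` is not yet measured. It differs from compound 3 in one place: morpholin-4-yl in place of thiomorpholin-4-yl on a thiocarbonyl carbon.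

For the measured compounds named here, no measured pair shows exactly this swap. Going by the values given here, the one step that involves the thiomorpholin-4-yl group is a 24-fold higher number from compound 2 to compound 3 (1.38 log units; beyond the scatter), a large change, which shows that what sits on the thiocarbonyl carbon can move the number a long way. Compound 1 carries the morpholin-4-yl group, though on a core without the fluorine, and gives a number well below that of compound 3. On that basis compound 4 is expected to show a moderate step toward stronger inhibition, a 4.3-fold lower number from compound 3 to compound 4 (0.63 log units; beyond the scatter). The estimate for compound 4 in this assay is 5000 nM, with a range from 1500 nM to 18000 nM.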

Compound 4, half-maximal inhibitory concentration: 22100 nM
Beside the measured number, compound 4's estimate is 4.4-fold (0.65 log units) below it; measured number above the stated range.
By their numbers in this assay, from the lowest: compound 2; then compound 1; then compounds 3 and 4 (each within the scatter of the next).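

In this assay, morpholin-4-yl in place of thiomorpholin-4-yl on the thiocarbonyl carbon gives a 1.0-fold higher number from compound 3 to compound 4 (0.01 log units; within the scatter) and so leaves the read-out unchanged within the scatter, which means that oxygen and sulfur in this six-membered ring cannot be told apart here. Pyrrolidin-1-yl stands apart from both, since morpholin-4-yl in its place gives a 25-fold higher number from compound 2 to compound 4 (1.39 log units; beyond the scatter) on top of the step already seen with thiomorpholin-4-yl. For the compounds shown here, the pair with and without fluorine also gives a first reading of the aromatic position: fluoro in place of hydrogen on an aromatic carbon gives a 4.7-fold higher number from compound 1 to compound 4 (0.67 log units; beyond the scatter) as a modest move toward weaker inhibition, and nothing measured here explains these steps.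

Going by these compounds, whether the fluoro step would be the same with pyrrolidin-1-yl stays open. So does how a piperidin-1-yl ring or an open-chain dimethylamino group would read on the thiocarbonyl carbon.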